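This account rests on a few compounds, and the source may have more. Where it says the series, first, only, none or still open, it means among the compounds named here.

Measured so far in an assay on brain for binding affinity to Neuronal acetylcholine receptor; alpha4/beta2 (Rattus norvegicus), read by radioligand binding; a higher number here means a weaker inhibitor, a lower number a stronger inhibitor:

Compound 1, `Cc1ccc(OC[C@@H]2CCN2)cn1`, gives 0.057 nM.
Compound 2, `COc1ccc(OC[C@@H]2CCN2)cn1`, gives 1.3 nM.
Compound 3, `Clc1cncc(OC[C@@H]2CCN2)c1`, gives 0.042 nM.

Compound 3 has the lowest number of the three in this assay. Its nearest neighbour is compound 1, whose number lies within the scatter of that of compound 3, so the two cannot be ordered. Among the measured compounds shown here, compound 2 stands far apart from both: the one counted step, a 23-fold higher number from compound 1 to compound 2 (1.36 log units; beyond the scatter), is large and well beyond the scatter.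

Compound 4, `CCCc1cncc(OC[C@@H]2CCN2)c1`, has not yet been measured. It differs from compound 3 in one place: propyl in place of chloro on an aromatic carbon. For the measured compounds named here, none of the measured steps involves a change of this kind, since the one step known exchanges methyl for methoxy on the core of compound 1, not chloro for propyl. Going by the values given here, what can be said is only that a large step in this assay has occurred once for a single change on the ring, and that a propyl group is the largest substituent in this set. The number for compound 4 is therefore expected to move upward from compound 3 by a moderate step, a 7.1-fold higher number from compound 3 to compound 4 (0.85 log units; beyond the scatter), with wide uncertainty. Compound 4 is estimated at 0.3 nM in this assay, in the range 0.05 nM to 3 nM.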

Compound 4, inhibition constant: 0.039 nM
The estimate for compound 4 lay 7.7-fold (0.89 log units) above the measured number; measured number outside the range, below it.
By their numbers in this assay, from the lowest: compounds 4, 3 and 1 (each within the scatter of the next); then compound 2.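

In this assay, the exchange at this aromatic carbon, two atoms from the ring nitrogen, gives a 1.1-fold lower number from compound 3 to compound 4 (0.03 log units; within the scatter) and so brings no readable change, although propyl has 3 heavy atoms where chloro has 1. The earlier step, a 23-fold higher number from compound 1 to compound 2 (1.36 log units; beyond the scatter), was large, but it involved other groups, so a single exchange on the ring does not always move the number far in this series. Nothing measured here explains why these two groups cannot be told apart.

The compounds shown leave open whether this position would accept a longer chain such as hexyl as it accepts propyl. They also leave open whether an amine or a carboxylic acid on the same carbon would keep the number in this range.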